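A few compounds are considered here, and "the series" means these few. Any claim that something is new, unique, unknown or untested is made for them only; others in the source may bear on it.

In a functional assay on the whole organism with Rattus norvegicus as the target, read by paw edema, with a stated time of 3 h, at a dose of 100 mg/kg by the oral route (on this read-out lower numbers stand for less inhibition and higher numbers for more inhibition at the one dose given (going by the name of the read-out)), compound 3 `CCc1ccc(-c2nc3ccccc3n2Cc2ccccc2)nc1` gives -18%, the lowest of the three numbers measured; compound 1 `CCc1ccc(-c2nc3ccccc3n2C)nc1` gives 5% and compound 2 `CCc1ccc(-c2nc3ccccc3n2-c2ccccc2)nc1` gives 12%. Compound 4 `CCc1ccc(-c2nc3ccccc3n2CC(=O)N2CCCC2)nc1` has not been measured, and it differs from compound 3 by (pyrrolidin-1-yl)carbonyl in place of phenyl on a saturated chain carbon bound to an aromatic nitrogen.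

Going by the values given here, no measured step exchanges a group on that saturated chain carbon for a (pyrrolidin-1-yl)carbonyl, so the closest guidance comes from the steps that put the phenyl there: a number 23 percentage points lower from compound 1 to compound 3 (beyond the scatter) and a number 30 percentage points lower from compound 2 to compound 3 (beyond the scatter). Among the compounds with values here, both fell beyond the scatter and in the same direction, so removing the phenyl from that carbon is expected to undo part of that drop, while the entering (pyrrolidin-1-yl)carbonyl has no precedent among the measured compounds. The step is therefore expected to be modest and upward, a number 20 percentage points higher from compound 3 to compound 4 (beyond the scatter). Compound 4 is expected to give 2% in this assay, with a range from -22% to 26%.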

Compound 4, a percentage reported as inhibition, in the whole organism at one dose (the size of the read-out at that dose, not a potency): -5%
Compound 4: the middle estimate sits 7 percentage points above what was measured; measured number inside the range.
By their numbers in this assay, from the lowest: compound 3; then compounds 4, 1 and 2 (each within the scatter of the next, the first and the last beyond it).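

In this assay, (pyrrolidin-1-yl)carbonyl in place of phenyl on the saturated chain carbon bound to an aromatic nitrogen reads a number 13 percentage points higher from compound 3 to compound 4 (beyond the scatter) and so shows that the low number of compound 3 does not hold for every group placed on that carbon. Set against hydrogen at the same carbon, the entering group reads a number 10 percentage points lower from compound 1 to compound 4 (within the scatter) and so brings no change that stands clear of the scatter, while ((pyrrolidin-1-yl)carbonyl)methyl in place of phenyl on the aromatic nitrogen reads a number 17 percentage points lower from compound 2 to compound 4 (beyond the scatter) and leaves the directly attached phenyl ahead. Nothing shown here accounts for these steps.

From the compounds shown here alone, how a carboxylic acid or an amine in place of the (pyrrolidin-1-yl)carbonyl would read remains open. So does the effect of a longer chain on the aromatic nitrogen.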